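From sulfamoyl to cyano on the shared core

The compounds below may be only part of what the source reports. "The series", "measured", "known", "first", "only" and "open" are said of these compounds alone.

Compound 1 `Fc1ccc(Nc2nncc3ccccc23)cc1`: 2.8 nM
Compound 2 `Cc1cc(NS(=O)(=O)c2ccc(Nc3nncc4ccccc34)cc2)no1`: 13 nM
Compound 3 `NS(=O)(=O)c1ccc(Nc2nncc3ccccc23)cc1`: 12 nM

In a functional assay on HeLa cells (Homo sapiens) for antiproliferative activity, read by sulforhodamine B assay, with a stated time of 72 h (a lower number here means a stronger inhibitor, a higher number a weaker inhibitor), compound 3 stands level with compound 2, as a 1.1-fold lower number from compound 2 to compound 3 (0.03 log units; within the scatter) shows, while compound 1 has the lowest number of the three. Compound 4 `N#Cc1ccc(Nc2nncc3ccccc23)cc1` has cyano in place of sulfamoyl on an aromatic carbon. Among the measured compounds shown here, no measured compound carries cyano. For the measured compounds named here, compound 1 gives the only measured change at this place, a 4.3-fold higher number from compound 1 to compound 3 (0.63 log units; beyond the scatter), and the change on the sulfonamide nitrogen offers little guidance here. A smaller step than that one, towards a lower number, is therefore expected. The expected move is a 2.4-fold lower number from compound 3 to compound 4 (0.38 log units; beyond the scatter). For compound 4 the estimated value is 5 nM, with an expected range from 1.8 nM to 15 nM.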

Compound 4, half-maximal inhibitory concentration: 1.5 nM
Compound 4: the middle estimate sits 3.3-fold (0.52 log units) above what was measured, outside the stated range (below it).
By their numbers in this assay, from the lowest: compounds 4 and 1 (each within the scatter of the next); then compounds 3 and 2 (each within the scatter of the next).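

In this assay, among the compounds shown here, the change from sulfamoyl to cyano on this aromatic carbon gives an 8.0-fold lower number from compound 3 to compound 4 (0.90 log units; beyond the scatter) and so goes further than the one earlier step at this place. Cyano and fluoro stand level here, with a 1.9-fold lower number from compound 1 to compound 4 (0.27 log units; within the scatter) within the scatter, so sulfamoyl alone among these three groups sits apart. Nothing at hand accounts for that gap. Going by these compounds, whether an amine or a carboxylic acid at this place would stay level with cyano and fluoro remains open, as does whether a methyl group would.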